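A halogen swap on a triazole analogue without a ketone

The compounds below may be only part of what the source reports. "The series", "measured", "known", "first", "only" and "open" are said of these compounds alone.

Compound 1, with structure `C=C1C(=O)[C@]23C[C@@]1(O)CC[C@H]2c1ccc(OS(=O)(=O)c2ccc(C)cc2)c(C)c1[C@@H]3Cn1cc(-c2ccccn2)nn1`, gives 320 nM in a functional assay on MCF7 cells (Homo sapiens) for cytotoxicity, read by MTT assay, with a stated time of 4 days; a lower number here means a stronger inhibitor, a higher number a weaker inhibitor.
Compound 2, with structure `C=C1C(=O)[C@]23C[C@@]1(O)CC[C@H]2c1ccc(OS(=O)(=O)c2ccc(C)cc2)c(C)c1[C@@H]3Cn1cc(-c2ccc(Cl)cc2)nn1`, gives 1440 nM in this assay.
Compound 3, with structure `C=C1C[C@]23C[C@@]1(O)CC[C@@H]2c1cccc(C)c1[C@@H]3Cn1cc(-c2ccc(Cl)cc2)nn1`, gives only > 20000 nM in this assay, which is a limit of the assay and not a number.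

Compound 3 is thus the one of the three for which no number is known; its value is the limit of > 20000 nM in this assay, at which 1 of the 3 values shown sits. Compound 4, with structure `C=C1C[C@]23C[C@@]1(O)CC[C@@H]2c1cccc(C)c1[C@@H]3Cn1cc(-c2ccc(F)cc2)nn1`, has not yet been measured. It differs from compound 3 by fluoro in place of chloro on an aromatic carbon. The only measured step among these compounds, a 4.5-fold higher number from compound 1 to compound 2 (0.65 log units; beyond the scatter), concerns a different exchange on a different core and so bears on the present change only loosely. Among the compounds with values here, no step that swaps one halogen for another on the same phenyl ring has been measured here. Because compound 3 returns only > 20000 nM, there is no starting number from which a step could be read. The step expected from compound 3 to compound 4 in this assay is a step that the limit leaves unreadable from compound 3 to compound 4, that is none beyond the scatter, with a good chance that compound 4 again returns only a limit. The estimate for compound 4 in this assay is 30000 nM, within a range from 8000 nM to 100000 nM.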

Compound 4, half-maximal inhibitory concentration: > 20000 nM
Compound 4 ended at the assay's limit; the forecaster's own chance of this, stated with the estimate: 75%; the middle value is on the limit's open side.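

Compound 3 and compound 4 both end at a limit of the assay, not at a number, in this assay, so no step can be read for fluoro in place of chloro on the phenyl ring: the limit of > 20000 nM in this assay, at which 2 of the 4 values shown sit.

The compounds shown leave open how compound 3 and compound 4 truly compare in this assay.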